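The source may hold more compounds than are shown below. What is called first, only, known or untested is meant among the compounds shown, and "the series" means these compounds.

Compound 2, `CCCCCCSc1nc(N)nc2c1ncn2/C=C1/CC1(CO)CO`, is the starting point of this step. In an ADME assay on Akata cells (Homo sapiens) for cytotoxicity, with a stated time of 7 days (on this read-out lower numbers stand for higher toxicity in this test and higher numbers for lower toxicity in this test), compound 2 gives > 20000 nM, which is a limit of the assay and not a number. Compound 1, `Nc1nc(N2CCCC2)c2ncn(/C=C3/CC3(CO)CO)c2n1`, shares the core and carries pyrrolidin-1-yl where compound 2 carries hexylsulfanyl. In this assay compound 1 gives > 24000 nM, again a limit. Among the compounds with values here, the only measured step, a step that the two limits leave unreadable from compound 1 to compound 2, therefore cannot be read in size or direction. Compound 3, `CCCCOc1nc(N)nc2c1ncn2/C=C1/CC1(CO)CO`, differs from compound 2 by butoxy in place of hexylsulfanyl on an aromatic carbon. Within the data shown here, no measured step bears directly on this change, and both values shown are limits, the limit of > 20000 nM in this assay, at which 1 of the 2 values shown sits, and (the limit of > 24000 nM in this assay, at which 1 of the 2 values shown sits), so compound 3 is expected to remain near those limits rather than show a readable step. The step that the limit leaves unreadable from compound 2 to compound 3 is accordingly expected to be small or unreadable. For compound 3 the estimate is 30000 nM, with a range from 10000 nM to 100000 nM.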

Compound 3, half-maximal cytotoxic concentration: > 20000 nM
Compound 3 was reported as a limit (the forecaster's own chance of this, stated with the estimate: 80%); the middle value does not contradict the limit.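

In this assay compound 3 gives > 20000 nM, which is a limit of the assay and not a number. The steps from compound 1 and from compound 2 to compound 3 cannot be read. The compounds shown leave open how the true values of these three compounds compare.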